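Linker extension on the benzamide arm of compound 1

The source may report more compounds than this note shows. Statements on the series, on what has been measured and on what is new or still open speak of the compounds shown alone.

Compound 1 `Nc1ccccc1NC(=O)c1ccc(Cn2cnc3c(Nc4ccccc4)nc(Cl)nc32)cc1` is assayed in a functional assay on HepG2 cells (Homo sapiens) for antiproliferative activity, read by CCK-8 assay, with a stated time of 72 h, tested at 2 uM (a higher number here means a stronger effect of the compound at the concentration tested, a lower number a weaker effect), where compound 1 gives 49.6%. Among the three measured compounds it stands second highest: compound 3 `CN1CCN(c2nc(Cl)nc3c2ncn3Cc2ccc(C(=O)Nc3ccccc3N)cc2)CC1` gives 60.4% and compound 2 `Nc1ccccc1NC(=O)c1ccc(Cn2cnc3c(Nc4ccc(-c5ccccn5)cc4)nc(Cl)nc32)cc1` gives 11.5%. The two measured steps both change the substituent on the shared core, a number 38.1 percentage points lower from compound 1 to compound 2 (beyond the scatter) and a number 10.8 percentage points higher from compound 1 to compound 3 (beyond the scatter). Compound 4 `Nc1ccccc1NC(=O)/C=C/c1ccc(Cn2cnc3c(Nc4ccccc4)nc(Cl)nc32)cc1` instead alters the benzamide arm: 2-((2-aminophenyl)carbamoyl)ethenyl in place of (2-aminophenyl)carbamoyl on an aromatic carbon. For the measured compounds named here, no measured step touches this part of the molecule, so neither step bears on the change, and the direction is open. A step within the scatter is therefore expected, a number 0.4 percentage points higher from compound 1 to compound 4 (within the scatter), with compound 4 estimated at 50% in this assay, in the range 25% to 75%.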

Compound 4, a percentage reported as inhibition, at one concentration (the size of the read-out at that concentration, not a potency): 16.4%
Beside the measured number, compound 4's estimate is 33.6 percentage points above it, and the stated range ends above it.
By their numbers in this assay, from the lowest: compounds 2 and 4 (each within the scatter of the next); then compound 1; then compound 3.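

For the compounds shown here, the benzamide arm is a sensitive position, which the earlier steps on the shared core could not show: in this assay, the ethenyl extension gives a number 33.2 percentage points lower from compound 1 to compound 4 (beyond the scatter). The entering group keeps the same hydrogen-bond donor and acceptor counts and the same aromatic ring, so the loss comes with a change that leaves those counts untouched. Nothing available accounts for this loss.

Still open, going by these compounds, is whether a saturated ethane-1,2-diyl link or a longer chain in this place gives a similar loss. Also open, on these data alone, is whether the ethenyl extension has the same effect with the 4-methylpiperazin-1-yl group of compound 3.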